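This account rests on a few compounds, and the source may have more. Where it says the series, first, only, none or still open, it means among the compounds named here.

Measured in a functional assay on PC-3 cells (Homo sapiens) for antiproliferative activity, read by sulforhodamine B assay; on this read-out higher numbers stand for weaker inhibition of growth and lower numbers for stronger inhibition of growth:

Compound 1 `CC(C)(C)CCOc1cccc(O)c1C(=O)/C=C/c1ccc(O)cc1`: 3220 nM
Compound 2 `O=C(/C=C/c1ccc(O)cc1)c1c(O)cccc1OCCC1CCCCC1`: > 30000 nM
Compound 3 `CC(C)CCOc1cccc(O)c1C(=O)/C=C/c1ccc(O)cc1`: 11500 nM

Of the two results that are true numbers, compound 3 holds the higher, with 11500 nM. Its nearest neighbour is compound 1, and the step between them is a 3.6-fold higher number from compound 1 to compound 3 (0.55 log units; beyond the scatter). Compound 2 gives only a limit of the assay, > 30000 nM.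

Compound 4 `O=C(/C=C/c1ccc(O)cc1)c1c(O)cccc1OCCC1CCCC1` has not yet been measured. It carries cyclopentyl in place of isopropyl on a saturated chain carbon, two bonds along the chain from an oxygen on an aromatic ring.

The closest guide is the step that links the cyclohexyl of compound 2 with the isopropyl of compound 3, an at least 2.6-fold lower number from compound 2 to compound 3 (0.41 log units; beyond the scatter). Since compound 4 also ends in a carbon ring, it is expected to lean toward compound 2 in this assay, though probably less far. The tert-butyl of compound 1 cautions against a simple trend, given an at least 9.3-fold higher number from compound 1 to compound 2 (0.96 log units; beyond the scatter).

The expected change is small and toward a higher number, possibly within the scatter: a 1.4-fold higher number from compound 3 to compound 4 (0.14 log units; within the scatter). For compound 4 the estimate is 16000 nM, with an expected range from 6000 nM to 30000 nM.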

Compound 4, concentration for 50% growth inhibition: 3480 nM
For compound 4 the middle estimate is 4.6-fold (0.66 log units) above the measured one; the measured number lies below the stated range.
By their numbers in this assay, from the lowest: compounds 1 and 4 (each within the scatter of the next); then compound 3. At a limit, above all of these: compound 2.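

In this assay, the position on a saturated chain carbon, two bonds along the chain from an oxygen on an aromatic ring, proves able to carry a carbon ring without loss: cyclopentyl in place of isopropyl gives a 3.3-fold lower number from compound 3 to compound 4 (0.52 log units; beyond the scatter), and cyclopentyl in place of tert-butyl gives a 1.1-fold higher number from compound 1 to compound 4 (0.03 log units; within the scatter), which leaves those two groups indistinguishable here. The position also separates one carbon ring from another, as cyclopentyl in place of cyclohexyl gives an at least 8.6-fold lower number from compound 2 to compound 4 (0.93 log units; beyond the scatter), so ending in a ring does not by itself decide the result. That step can only be read as a minimum, as compound 2 stands as a limit of the assay: the limit of > 30000 nM in this assay, at which 1 of the 4 values shown sits.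

The compounds shown leave open how a smaller ring such as cyclobutyl or cyclopropyl would fall in this series, and whether the sharp drop from cyclopentyl to cyclohexyl would persist with a longer chain carrying the ring. They also leave open whether an amine or an ether oxygen within the ring would be accepted at this position.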